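Cyclobutyl for ethyl on the amide carbonyl

A few compounds are considered here, and "the series" means these few. Any claim that something is new, unique, unknown or untested is made for them only; others in the source may bear on it.

Measured compounds in an ADME assay on LLC-PK1 cells (Sus scrofa) for permeability; on this read-out lower numbers stand for lower permeability and higher numbers for higher permeability:
compound 1 `CCn1c(-c2cnc(C)nc2)nc2c(N[C@H]3CCN(C(=O)N4CC(OC)C4)C3)ncnc21` gives 10 10^-6 cm/s
compound 2 `CCn1c(-c2cnc(C)nc2)nc2c(N[C@H]3CCN(C(=O)[C@H]4C[C@@H](OC)C4)C3)ncnc21` gives 10 10^-6 cm/s
compound 3 `CCC(=O)N1CC[C@H](Nc2ncnc3c2nc(-c2cnc(C)nc2)n3CC)C1` gives 21 10^-6 cm/s

Compound 3 stands highest of the three numbers in this assay, with compound 1 and compound 2 at a modest distance: a 2.1-fold higher number from compound 1 to compound 3 (0.32 log units; beyond the scatter) and a 2.1-fold higher number from compound 2 to compound 3 (0.32 log units; beyond the scatter), while no change at the digits printed from compound 1 to compound 2 (within the scatter). Compound 4 `CCn1c(-c2cnc(C)nc2)nc2c(N[C@H]3CCN(C(=O)C4CCC4)C3)ncnc21` has not yet been measured. It differs from compound 3 in one place: cyclobutyl in place of ethyl on a carbonyl carbon. The step from compound 2 to compound 3 bears most closely on this, since it also exchanged a four-membered ring on the carbonyl carbon for ethyl, but that ring carried a methoxy group and cyclobutyl does not. The account therefore expects the number for compound 4 to stay near that of compound 3, a step of a 1.0-fold higher number from compound 3 to compound 4 (0.02 log units; within the scatter) being within the scatter, with an estimate of 22 10^-6 cm/s and a range from 12 10^-6 cm/s to 40 10^-6 cm/s.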

Compound 4, apparent permeability: 32 10^-6 cm/s
Beside the measured number, compound 4's estimate is 1.5-fold (0.16 log units) below it, within the range that was stated.
By their numbers in this assay, from the lowest: compounds 1 and 2 (each within the scatter of the next); then compounds 3 and 4 (each within the scatter of the next).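

In this assay the exchange of ethyl for cyclobutyl on the carbonyl carbon gives a 1.5-fold higher number from compound 3 to compound 4 (0.18 log units; within the scatter) and so does not part the bare four-membered ring from the open chain. Removing the methoxy from the ring gives a 3.2-fold higher number from compound 2 to compound 4 (0.51 log units; beyond the scatter), and replacing 3-methoxyazetidin-1-yl with cyclobutyl gives a 3.2-fold higher number from compound 1 to compound 4 (0.51 log units; beyond the scatter), so the lower numbers here go with the methoxy-bearing rings, not with a ring as such. Nothing available explains these steps. Going by these compounds, whether an amine or a carboxylic acid on the cyclobutyl ring, or a longer chain in place of ethyl, would hold the number remains open.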